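A few compounds are considered here, and "the series" means these few. Any claim that something is new, unique, unknown or untested is made for them only; others in the source may bear on it.

Measured compounds:
compound 1, `CCCNC(=O)N[C@H]1CCN(c2cccc3c2CCO3)C1` — 17.7 nM
compound 2, `CCCNC(=O)N[C@@H]1CCN(c2cccc3c2CCO3)C1` — 4.4 nM

Both compounds were tested in an assay on NIH3T3 cells for binding affinity to melatonin receptor type 1A (Homo sapiens); a lower number here means a stronger inhibitor, a higher number a weaker inhibitor. Compound 1 has the highest of the two numbers; its nearest neighbour is compound 2, and the step of a 4.0-fold lower number from compound 1 to compound 2 (0.60 log units; beyond the scatter) rests on (the fact that compounds 1 and 2 differ only in the configuration as drawn), nothing else being different between them.

The step followed here leads from compound 1 to compound 3, `O=C(NC1CC1)N[C@H]1CCN(c2cccc3c2CCO3)C1`, which has not yet been measured. The change is cyclopropyl in place of propyl on an amide-type nitrogen. In words, cyclopropyl takes the place of propyl on an amide-type nitrogen; the count of carbon atoms, donors and acceptors is unchanged, the only difference being that the three carbons now form a three-membered ring.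

Among the measured compounds shown here, no measured step bears on this change: the single step known, from compound 1 to compound 2, concerns configuration alone and leaves the propyl group untouched. There is therefore no basis from these two compounds for expecting a shift in this assay in either direction, and the likeliest outcome is a step no larger than the scatter. Compound 3 is accordingly estimated at 15 nM, with a range from 4 nM to 60 nM, which means an expected step of a 1.2-fold lower number from compound 1 to compound 3 (0.07 log units; within the scatter).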

Compound 3, inhibition constant: 21 nM
Beside the measured number, compound 3's estimate is 1.4-fold (0.15 log units) below it, and the stated range covers the measured number.
By their numbers in this assay, from the lowest: compound 2; then compounds 1 and 3 (each within the scatter of the next).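

In this assay, placing cyclopropyl in the position of propyl on the amide-type nitrogen gives a 1.2-fold higher number from compound 1 to compound 3 (0.07 log units; within the scatter), so compound 1 and compound 3 cannot be told apart in this measurement. Among the compounds shown here, this is the first information about the group on this nitrogen, as the earlier comparison changed only the configuration at a saturated ring carbon; here, tying the open propyl chain into a three-membered ring leaves the binding number within ordinary measurement scatter, at least with the shared core drawn as in compound 1. What is known about these compounds says nothing about the reason for this result.

For the compounds shown here, still open is whether cyclopropyl would give the same picture on the configuration of compound 2, since the only comparison of the two configurations carries propyl. As far as these compounds go, it is also open how much larger or different the group on this nitrogen can become, for example a longer chain such as butyl, a branched isopropyl group or a phenyl ring, before the binding number moves beyond the scatter.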